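From methylamino to ethylamino on a shared core

This account rests on a few compounds, and the source may have more. Where it says the series, first, only, none or still open, it means among the compounds named here.

- Compound 1 `COc1ccc(C(=O)c2ccc(OC)c3c2OC(C)(C)C=C3)c(NC(=O)CO)c1`: 80 nM
- Compound 2 `COc1ccc(C(=O)c2ccc(OC)c3c2OC(C)(C)C=C3)c(NC(=O)CN)c1`: 270 nM
- Compound 3 `CNCC(=O)Nc1cc(OC)ccc1C(=O)c1ccc(OC)c2c1OC(C)(C)C=C2`: 620 nM

These values come from a functional assay on A549 cells (Homo sapiens) for antiproliferative activity, read by MTT assay, with a stated time of 48 h; a higher number here means a weaker inhibitor, a lower number a stronger inhibitor. Compound 3 is the weakest of the three at 620 nM. Compound 4 `CCNCC(=O)Nc1cc(OC)ccc1C(=O)c1ccc(OC)c2c1OC(C)(C)C=C2` differs from compound 3 by methyl in place of hydrogen on a saturated chain carbon bound to an amine nitrogen, turning methylamino into ethylamino. Within the data shown here, no ethylamino compound has been measured, so the closest guide is the single step of a 2.3-fold higher number from compound 2 to compound 3 (0.36 log units; beyond the scatter), where methyl replaced hydrogen on an amine nitrogen. The steps of a 3.4-fold higher number from compound 1 to compound 2 (0.53 log units; beyond the scatter) and a 7.8-fold higher number from compound 1 to compound 3 (0.89 log units; beyond the scatter) also moved upward. A similarly modest rise is therefore expected, an estimated 1.6-fold higher number from compound 3 to compound 4 (0.21 log units; within the scatter). Compound 4 is expected at about 1000 nM, within an estimated range of 450 nM to 2400 nM.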

Compound 4, half-maximal inhibitory concentration: 1050 nM
Estimate against measurement, compound 4: 1.1-fold (0.02 log units) below, within the range that was stated.
By their numbers in this assay, from the lowest: compound 1; then compound 2; then compounds 3 and 4 (each within the scatter of the next).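

Going from methylamino to ethylamino gives a 1.7-fold higher number from compound 3 to compound 4 (0.23 log units; within the scatter) in this assay, so this added methyl on a saturated chain carbon bound to an amine nitrogen has no effect that can be told from scatter. The wider comparisons are clearer: ethyl in place of hydrogen on the amine nitrogen gives a 3.9-fold higher number from compound 2 to compound 4 (0.59 log units; beyond the scatter), while ethylamino in place of hydroxy gives a 13-fold higher number from compound 1 to compound 4 (1.12 log units; beyond the scatter), the largest step in this set. Nothing shown explains these steps.

As far as these compounds go, whether a propylamino group, a dimethylamino group or a carboxylic acid would behave like these amines or like the hydroxy of compound 1 remains open.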